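The source may report more compounds than this note shows. Statements on the series, on what has been measured and on what is new or still open speak of the compounds shown alone.

In a functional assay on A549 cells (Homo sapiens) for antiproliferative activity, read by MTT assay (on this read-out lower numbers stand for stronger inhibition and higher numbers for weaker inhibition), three compounds have been measured so far:

compound 1 `COC(=O)N1CCCc2cc(S(=O)(=O)N3CC(c4ccccc4)NC3=O)ccc21` — 1150 nM
compound 2 `C=CCOC(=O)N1CCCc2cc(S(=O)(=O)N3CC(c4ccccc4)NC3=O)ccc21` — 4310 nM
compound 3 `O=C(c1ccccc1)N1CCCc2cc(S(=O)(=O)N3CC(c4ccccc4)NC3=O)ccc21` — 8140 nM

Compound 1 gives the lowest number of the three. The step to compound 2 is a 3.7-fold higher number from compound 1 to compound 2 (0.57 log units; beyond the scatter), and the step to compound 3 is a 7.1-fold higher number from compound 1 to compound 3 (0.85 log units; beyond the scatter); between compound 2 and compound 3 the step is a 1.9-fold higher number from compound 2 to compound 3 (0.28 log units; within the scatter).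

Compound 4 `O=C1NC(c2ccccc2)CN1S(=O)(=O)c1ccc2c(c1)CCCN2C(=O)C(F)(F)F` has not yet been measured. It differs from compound 1 in one place: trifluoromethyl in place of methoxy on a carbonyl carbon. Both measured steps that start from compound 1 alter the methoxycarbonyl end of the shared core, one by extending the chain on its oxygen and one by exchanging the methoxy for phenyl, and both gave higher numbers in this assay. The change in compound 4 exchanges the methoxy as well, so a higher number than compound 1 is expected, though these two steps do not settle how large it should be. A modest rise, nearer the smaller of the two measured steps than the larger, is taken as the most likely outcome.

Compound 4 is therefore expected to give 2600 nM, with a range from 1000 nM to 7000 nM. This corresponds to an expected step of a 2.3-fold higher number from compound 1 to compound 4 (0.35 log units; beyond the scatter).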

Compound 4, half-maximal inhibitory concentration: > 20000 nM
Compound 4 ended at the assay's limit; the forecaster's own chance of this, stated with the estimate: 5%; at least 7.6-fold (0.88 log units) between middle value and limit.
By their numbers in this assay, from the lowest: compound 1; then compounds 2 and 3 (each within the scatter of the next). At a limit, above all of these: compound 4.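

In this assay compound 4 gives a limit of the read-out and not a number: the limit of > 20000 nM in this assay, at which 1 of the 4 values shown sits.

Trifluoromethyl in place of methoxy on this carbonyl carbon gives an at least 17-fold higher number from compound 1 to compound 4 (1.24 log units; beyond the scatter), a larger step than either change seen earlier at this position. The earlier compounds shown here showed only moderate rises, and this result shows that the group on this carbonyl carbon can carry the number well past them, with an at least 2.4-fold higher number from compound 3 to compound 4 (0.39 log units; beyond the scatter) and an at least 4.6-fold higher number from compound 2 to compound 4 (0.66 log units; beyond the scatter), whereas allyloxy and phenyl lie within the scatter of each other.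

The true value of compound 4 remains unknown, so these steps can be read only as lower bounds, and the compounds shown do not separate the effect of the fluorine atoms from that of losing the oxygen-linked group, as compound 3 also lacks that oxygen and yet stays within the measurable range. As far as these compounds go, a plain methyl or an amine such as dimethylamino on the same carbonyl carbon would bear on that question, and whether any group here gives a lower number than compound 1 also stays open.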